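The source may hold more compounds than are shown below. What is called first, only, known or untested is meant among the compounds shown, and "the series" means these compounds.

Within the data shown here, compound 1 `CCCCn1nc(C(=O)N[C@H]2COc3ccccc3N(C)C2=S)nc1Cc1ccccc1` gives 510 nM in a functional assay on HT-29 cells (Homo sapiens) for inhibition, read by luminescence and CellTiter-Glo, with a stated time of 24 h (a higher number here means that more compound is needed for the effect, a lower number that less compound is needed), the lowest of the two numbers measured so far. Compound 2 `CN1C(=S)[C@@H](NC(=O)c2nc(Cc3ccccc3)n(C3CCCCC3)n2)COc2ccccc21` gives 4000 nM; the step of a 7.8-fold higher number from compound 1 to compound 2 (0.89 log units; beyond the scatter) accompanied cyclohexyl in place of butyl on an aromatic nitrogen. Compound 3 `CN1C(=S)[C@@H](NC(=O)c2nc(Cc3ccccc3)n(CC3COC3)n2)COc2ccccc21` differs from compound 1 by oxetan-3-yl in place of propyl on a saturated chain carbon bound to an aromatic nitrogen. Among the measured compounds shown here, the one measured step alters the same substituent on that nitrogen and raised the number, so for compound 3 a modest rise beyond the scatter is expected, as a 2.2-fold higher number from compound 1 to compound 3 (0.33 log units; beyond the scatter). The estimate for compound 3 is 1100 nM, with a range from 400 nM to 3200 nM.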

Compound 3, half-maximal effective concentration: 2830 nM
Compound 3: middle estimate off by 2.6-fold (0.41 log units), on the low side; the measured number falls inside the stated range.
By their numbers in this assay, from the lowest: compound 1; then compounds 3 and 2 (each within the scatter of the next).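

On the aromatic nitrogen, replacing the butyl of compound 1 with a ring-bearing group has now raised the number twice: (oxetan-3-yl)methyl gives a 5.5-fold higher number from compound 1 to compound 3 (0.74 log units; beyond the scatter). The two ring-bearing groups cannot be told apart, with a 1.4-fold lower number from compound 2 to compound 3 (0.15 log units; within the scatter), so the oxygen-containing four-membered ring recovers nothing relative to cyclohexyl, and the open chain of compound 1 keeps the lowest number of the three. The data at hand offer no explanation for this loss. From the compounds shown here alone, whether an open chain other than butyl, such as ethyl or hexyl, would match or improve on compound 1 remains open. So does the effect of an amine at the end of the chain.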